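Dimethylamino for butoxy on the dibromophenyl hydrazide

A few compounds are considered here, and "the series" means these few. Any claim that something is new, unique, unknown or untested is made for them only; others in the source may bear on it.

Compound 1 `CCCCOc1ccc(C(=O)NNc2c(Br)cccc2Br)cc1` has been tested in a toxicity assay on MDCK cells (Canis lupus familiaris) for cytotoxicity, read by CCK-8 assay, with a stated time of 48 h; a higher number here means that more compound is tolerated, a lower number that less compound is tolerated. In this assay compound 1 gives only a limit of the assay, > 100000 nM, and no number. The unmeasured analogue is compound 4 `CN(C)c1ccc(C(=O)NNc2c(Br)cccc2Br)cc1`, which differs from compound 1 by dimethylamino in place of butoxy on an aromatic carbon. The closest pair already measured is compound 2 `CCCc1ccc(C(=O)NNc2c(Cl)cccc2Cl)cc1` and compound 3 `CN(C)c1ccc(C(=O)NNc2c(Cl)cccc2Cl)cc1`, where the change is dimethylamino in place of propyl on an aromatic carbon. In this assay compound 2 also stands at a limit of the assay, > 100000 nM. Compound 3 likewise reaches only a limit, > 100000 nM. The step that the two limits leave unreadable from compound 2 to compound 3 therefore cannot be sized, and all that can be said of the series is the limit of > 100000 nM in this assay, at which 3 of the 3 values shown sit. With every value at the same limit, no shift beyond the scatter is expected for the step to compound 4; the step that the limit leaves unreadable from compound 1 to compound 4 is an estimate only. Compound 4 is expected at 150000 nM, most likely between 80000 nM and 400000 nM, and most probably again reported as a limit.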

Compound 4, half-maximal cytotoxic concentration: > 100000 nM
Compound 4 ended at the assay's limit; the forecaster's own chance of this, stated with the estimate: 80%; the middle value is on the limit's open side.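

Among the compounds shown here, no step from compound 1 to compound 4 can be read in this assay, as both stand only at a limit of the assay: the limit of > 100000 nM in this assay, at which 4 of the 4 values shown sit.

The compounds shown leave open how far beyond that limit each one lies, and whether dimethylamino in place of butoxy changes tolerance at all.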